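Swapping Fluoro for Trifluoromethyl: What to Expect

The source may report more compounds than this note shows. Statements on the series, on what has been measured and on what is new or still open speak of the compounds shown alone.

Compound 1 `CC[C@H](C)[C@H](NC(=O)/C=C/c1ccccc1Cl)C(=O)OC` gives 645 nM in an assay on isolated protein for inhibition of Nitric oxide synthase, inducible (Homo sapiens), with a stated time of 1 h; on this read-out higher numbers stand for weaker inhibition and lower numbers for stronger inhibition.
Compound 2 `CC[C@H](C)[C@H](NC(=O)/C=C/c1ccc(Cl)cc1)C(=O)OC` gives 916 nM in this assay.
Compound 3 `CC[C@H](C)[C@H](NC(=O)/C=C/c1ccc(F)cc1)C(=O)OC` gives 421 nM in this assay.

Compound 3 has the lowest of the three numbers: a 1.5-fold lower number from compound 1 to compound 3 (0.19 log units; within the scatter) lies within the scatter, while a 2.2-fold lower number from compound 2 to compound 3 (0.34 log units; beyond the scatter) is a modest but real step. Compound 4 `CC[C@H](C)[C@H](NC(=O)/C=C/c1ccc(C(F)(F)F)cc1)C(=O)OC` differs from compound 3 by a single change: trifluoromethyl in place of fluoro on an aromatic carbon. Within the data shown here, the only measured step that speaks to a change at this aromatic carbon is a 2.2-fold lower number from compound 2 to compound 3 (0.34 log units; beyond the scatter), in which fluoro replaced chloro. Among the measured compounds shown here, no measured compound carries a trifluoromethyl, so the expectation rests on that one step alone. A move from fluoro to trifluoromethyl is therefore expected to give a modest step to a higher number, a 1.9-fold higher number from compound 3 to compound 4 (0.28 log units; within the scatter), in this assay. Compound 4 is estimated at 800 nM, with a range from 300 nM to 2200 nM.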

Compound 4, half-maximal inhibitory concentration: 178 nM
Compound 4: middle estimate off by 4.5-fold (0.65 log units), on the high side; measured number below the stated range.
By their numbers in this assay, from the lowest: compound 4; then compounds 3, 1 and 2 (each within the scatter of the next, the first and the last beyond it).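

Trifluoromethyl on this aromatic carbon gives stronger inhibition than fluoro, with a 2.4-fold lower number from compound 3 to compound 4 (0.37 log units; beyond the scatter), so a lower number at this position does not depend on keeping the smaller fluoro. Against chloro, the change gives a 5.1-fold lower number from compound 2 to compound 4 (0.71 log units; beyond the scatter), which places compound 4 well clear of compound 2. Among these three groups on the same carbon, the order from lowest number to highest is trifluoromethyl, fluoro, chloro.

From the compounds shown here alone, how a nitrile or a methoxy group on this carbon would fit into that order remains open. Nothing available here explains the order itself.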